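The source may hold more compounds than are shown below. What is called first, only, known or untested is meant among the compounds shown, and "the series" means these compounds.

Working notes on the series, read-out a functional assay on KB cells (Homo sapiens) for cytotoxicity; on this read-out higher numbers stand for weaker inhibition and lower numbers for stronger inhibition. On the shared core, compound 1 (`COc1ccc(S(=O)(=O)N2CCc3cccc(NC(=O)c4ccc(F)cc4)c32)cc1`) gives 85 nM, compound 2 (`COc1ccc(S(=O)(=O)N2CCc3cccc(NC(C)=O)c32)cc1`) gives 90 nM and compound 3 (`COc1ccc(S(=O)(=O)N2CCc3cccc(NC(=O)c4ccccc4)c32)cc1`) gives 180 nM. Compound 3 is separated from only one of the other two, with a 2.1-fold higher number from compound 1 to compound 3 (0.33 log units; beyond the scatter), a modest gap that involves a single fluoro. Its other gap, a 2.0-fold higher number from compound 2 to compound 3 (0.30 log units; within the scatter), does not separate the pair.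

The next entry is compound 4 (`COc1ccc(S(=O)(=O)N2CCc3cccc(NC(=O)c4ccco4)c32)cc1`), with furan-2-yl in place of phenyl on a carbonyl carbon. Among the compounds with values here, no furan-2-yl example has been measured, so the closest guides are the other exchanges at this carbonyl carbon. These are a 2.0-fold higher number from compound 2 to compound 3 (0.30 log units; within the scatter), as above, and a 1.1-fold higher number from compound 1 to compound 2 (0.02 log units; within the scatter). Neither is large, even though methyl and the aromatic groups differ far more than the two rings do here. A step beyond the scatter is therefore not expected in this assay, though a slightly lower number is the mild expectation. The expected step is a 1.5-fold lower number from compound 3 to compound 4 (0.18 log units; within the scatter). For compound 4 the estimate is 120 nM, with an expected range of 50 nM to 300 nM.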

Compound 4, half-maximal inhibitory concentration: 9.2 nM
Beside the measured number, compound 4's estimate is 13-fold (1.12 log units) above it; the whole stated range lies above it.
By their numbers in this assay, from the lowest: compound 4; then compounds 1, 2 and 3 (each within the scatter of the next, the first and the last beyond it).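

At this carbonyl carbon the choice of ring matters far more than the earlier exchanges suggested: in this assay there is a 20-fold lower number from compound 3 to compound 4 (1.29 log units; beyond the scatter), whereas the exchange of methyl for phenyl gave only a 2.0-fold higher number from compound 2 to compound 3 (0.30 log units; within the scatter). The furan-2-yl group also stands apart from the other two substituents, with a 9.8-fold lower number from compound 2 to compound 4 (0.99 log units; beyond the scatter) and a 9.2-fold lower number from compound 1 to compound 4 (0.97 log units; beyond the scatter), so a five-membered aromatic ring with one hetero atom separates from methyl as well as from both six-membered carbon rings. No measurement shown here bears on the reason for this step.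

On these data alone, it remains open whether the step goes with the ring oxygen or with the five-membered ring itself, which thiophen-2-yl or furan-3-yl at this carbonyl carbon would help to separate. A saturated tetrahydrofuran-2-yl group would test whether the aromatic ring is needed at all.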